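Cytotoxicity notes on two measured compounds and one proposed

The source may report more compounds than this note shows. Statements on the series, on what has been measured and on what is new or still open speak of the compounds shown alone.

compound 1 `COc1ccc2nc(NC(=O)c3cn(-c4ccccc4)nc3-c3ccccc3)sc2c1`: > 50000 nM
compound 2 `O=C(Nc1nc2ccc(F)cc2s1)c1cn(-c2ccccc2)nc1-c1ccc(Cl)cc1`: > 50000 nM

In an ADME assay on HEK-293T cells (Homo sapiens) for cytotoxicity, read by MTT assay, with a stated time of 72 h (a higher number here means a weaker inhibitor, a lower number a stronger inhibitor), compound 1 gives only a limit of the assay, > 50000 nM, and not a number. Compound 2 likewise reaches no number in this assay, its value of > 50000 nM being a limit. Among the measured compounds shown here, both measured values therefore sit at the same point, and the limit of > 50000 nM in this assay, at which 2 of the 2 values shown sit, is the only evidence on where compound 2 stands; no step between measured compounds can be read from it.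

Compound 3 `COc1ccc2nc(NC(=O)c3cn(-c4ccccc4)nc3-c3ccc(Cl)cc3)sc2c1` differs from compound 2 by methoxy in place of fluoro on an aromatic carbon. Nothing measured here bears on that exchange. Compound 3 is expected to remain at the limit, estimated at 80000 nM with a range of 40000 nM to 200000 nM. The step expected is a step that the limit leaves unreadable from compound 2 to compound 3, none beyond the usual scatter, and most likely the assay again reports only a limit.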

Compound 3, half-maximal inhibitory concentration: 29600 nM
Estimate against measurement, compound 3: 2.7-fold (0.43 log units) above; measured number below the stated range.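

Among the compounds shown here, compound 3 is the first compound to give a number rather than a limit in this assay, and it carries methoxy and chloro together. Methoxy in place of fluoro on an aromatic carbon gives an at least 1.6-fold lower number from compound 2 to compound 3 (0.22 log units; that floor lies within the scatter), and chloro in place of hydrogen on an aromatic carbon gives an at least 1.6-fold lower number from compound 1 to compound 3 (0.22 log units; that floor lies within the scatter). Both steps are floors, so neither change has a fixed size, and the other two compounds offer no number to set against compound 3: the limit of > 50000 nM in this assay, at which 2 of the 3 values shown sit.

From the compounds shown here alone, it remains open whether the number for compound 3 depends on methoxy and chloro standing together or on either group alone. Also open, going by these compounds, is how an amine or a carboxylic acid in place of methoxy on this aromatic carbon would read in this assay.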